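The source may report more compounds than this note shows. Statements on the series, on what has been measured and on what is new or still open speak of the compounds shown alone.

Measured in an ADME assay on microsomes from liver (Homo sapiens) for metabolic stability, with a stated time of 10 min; on this read-out higher numbers stand for a more stable compound and lower numbers for a less stable compound:
- compound 1 `CC(=O)N1CCC(O)(C(=O)N2CC[C@](c3ccc(C(OCc4c(F)cccc4F)(C(F)(F)F)C(F)(F)F)cc3)(S(=O)(=O)c3ccc(F)cc3)C2)CC1`: 16%
- compound 2 `CC(=O)N1CCN(C(=O)N2CC[C@](c3ccc(C(OCc4c(F)cccc4C#N)(C(F)(F)F)C(F)(F)F)cc3)(S(=O)(=O)c3ccc(F)cc3)C2)CC1`: 0%
- compound 3 `O=C(O)[C@H]1CC[C@H](C(=O)N2CC[C@](c3ccc(C(OCc4ccccc4OC(F)(F)F)(C(F)(F)F)C(F)(F)F)cc3)(S(=O)(=O)c3ccc(F)cc3)C2)CC1`: 93%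

Compound 3 stands highest of the three, and its gaps to the other two both lie beyond the usual scatter of this kind of measurement. The next compound to consider is compound 4 `COc1cccc(F)c1COC(c1ccc([C@]2(S(=O)(=O)c3ccc(F)cc3)CCN(C(=O)[C@H]3CC[C@H](C(=O)O)CC3)C2)cc1)(C(F)(F)F)C(F)(F)F`, which differs from compound 3 in one place: 2-fluoro-6-methoxyphenyl in place of 2-(trifluoromethoxy)phenyl on a saturated chain carbon bound to an oxygen on a saturated carbon. In words, 2-fluoro-6-methoxyphenyl replaces 2-(trifluoromethoxy)phenyl on a saturated chain carbon bound to an oxygen on a saturated carbon. For the measured compounds named here, no pair of measured compounds differs in only one place, so the data give no direct measure of what a single swap of this kind does. The expectation therefore starts from compound 3 at 93%, close to the top of the scale, which leaves little room to rise. A moderate downward move in this assay is expected, and the estimated change is a number 11 percentage points lower from compound 3 to compound 4 (beyond the scatter). For compound 4 the estimate is 82%, with an expected range from 55% to 97%.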

Compound 4, percent of the compound remaining: 82%
Beside the measured number, compound 4's estimate shows no gap at the digits printed, within the range that was stated.
By their numbers in this assay, from the lowest: compound 2; then compound 1; then compound 4; then compound 3.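

For the compounds shown here, compound 3 and compound 4 form the first pair here that differs in only one place, so this assay now gives a direct reading of a single swap: 2-fluoro-6-methoxyphenyl in place of 2-(trifluoromethoxy)phenyl gives a number 11 percentage points lower from compound 3 to compound 4 (beyond the scatter). The step is modest, and compound 4 at 82% shows that a high reading can survive this change at this place. Nothing available explains why the number moved.

This single step cannot separate the effect of the entering fluorine from that of the entering methoxy. Also open, on these data alone, is how the reading would respond at this place to phenyl carrying an amine or a longer chain such as ethoxy.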